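A few compounds are considered here, and "the series" means these few. Any claim that something is new, unique, unknown or untested is made for them only; others in the source may bear on it.

Measured in a functional assay on NCI-H460 cells (Homo sapiens) for cytotoxicity, with a stated time of 48 h; a higher number here means a weaker inhibitor of growth, a lower number a stronger inhibitor of growth:

Compound 1 `CN(C)/N=C/c1ccc(C2=CC(=O)c3ccccc3C2=O)o1` gives 6800 nM.
Compound 2 `CN(C)/N=C/c1ccc(C2=C(Cl)C(=O)c3ccccc3C2=O)o1` gives 10900 nM.
Compound 3 `CN(C)/N=C/c1ccc(-c2c(O)ccc(O)c2C=O)o1` gives 93000 nM.

Compound 3 stands at the highest number of the three. Its value lies beyond the scatter from that of compound 2, which is the nearest, and further still from that of compound 1; in this assay compound 3 is therefore the weakest inhibitor of growth among the measured set.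

Compound 4 `O=Cc1ccc(-c2c(O)ccc(O)c2C=O)o1` is the next step from compound 3. The change is a group of 2 heavy atoms (1 carbon, 1 oxygen; no ring) in place of a group of 5 heavy atoms (3 carbon, 2 nitrogen; no ring), on an aromatic carbon; the position is on an aromatic carbon of a five-membered aromatic ring with 1 oxygen, next to the ring oxygen, two ring bonds from the ring atom that bears a large group.

Among the compounds with values here, no measured step touches this position or this kind of exchange. Within the data shown here, the only single-point step on record, a 1.6-fold higher number from compound 1 to compound 2 (0.20 log units; within the scatter), concerns a chloro in place of hydrogen on a different part of the core and offers no guidance here. With nothing to lean on, the step to compound 4 is expected to stay within the scatter, a 1.0-fold lower number from compound 3 to compound 4 (0.01 log units; within the scatter). For compound 4 the estimate in this assay is 90000 nM, with a range from 30000 nM to 300000 nM.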

Compound 4, concentration for 50% growth inhibition: 80200 nM
Estimate against measurement, compound 4: 1.1-fold (0.05 log units) above; the range from low to high includes it.
By their numbers in this assay, from the lowest: compounds 1 and 2 (each within the scatter of the next); then compounds 4 and 3 (each within the scatter of the next).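

In this assay, formyl in place of the group of 5 heavy atoms (3 carbon, 2 nitrogen) on this aromatic carbon gives a 1.2-fold lower number from compound 3 to compound 4 (0.06 log units; within the scatter). Within the data shown here, this is the first measured change at this position, and on the core of compound 3 the read-out does not separate the two groups, even though they differ in heavy atoms and in hydrogen-bond acceptors as counted. No evidence on the reason for this result is at hand.

From the compounds shown here alone, whether other groups at this position, such as an amine, a carboxylic acid or a longer chain, would also stay within the scatter remains open. The compounds shown also leave open whether the same exchange would give a similar step on the core of compound 1.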